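This account rests on a few compounds, and the source may have more. Where it says the series, first, only, none or still open, it means among the compounds named here.

Measured compounds:
compound 1, `C=C1CC[C@H]2[C@@](C)(CCC(=O)[C@@]2(C)COC(C)=O)[C@@H]1C/C=C1/C(=O)OC[C@H]1Oc1c(Cl)cc(Cl)c2cccnc12`, 64700 nM
compound 2, `C=C1CC[C@@H]2[C@](C)(COC(C)=O)[C@H](O)CC[C@@]2(C)[C@@H]1C/C=C1/C(=O)OC[C@@H]1Oc1cccc2cccnc12`, 27500 nM
compound 3, `C=C1CC[C@@H]2[C@](C)(COC(C)=O)[C@H](O)CC[C@@]2(C)[C@@H]1C/C=C1/C(=O)OC[C@@H]1Oc1c(Cl)cc(Cl)c2cccnc12`, 51900 nM

All three were tested in an ADME assay on Vero cells (Chlorocebus sabaeus) for cytotoxicity, read by MTT assay, with a stated time of 48 h; on this read-out higher numbers stand for lower toxicity in this test and lower numbers for higher toxicity in this test. Compound 1 sits at the high end of these values; against compound 3 the gap is within the usual scatter, against compound 2 it lies beyond it. Among the compounds with values here, the only measured step between neighbours, a 1.9-fold higher number from compound 2 to compound 3 (0.28 log units; within the scatter), concerns a change of the aromatic group on the oxygen and not a change in configuration.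

Compound 4, `C=C1CC[C@H]2[C@@](C)(CCC(=O)[C@@]2(C)COC(C)=O)[C@@H]1C/C=C1/C(=O)OC[C@@H]1Oc1c(Cl)cc(Cl)c2cccnc12`, differs from compound 1 at a single point: the two compounds have the same atoms and bonds and differ only in configuration as drawn: 1 of 6 stereo elements differ; a stereocentre at a saturated ring carbon is drawn S in compound 1 and R in compound 4. Within the data shown here, no measured pair among the three shows what an inversion at a saturated ring carbon does in this assay, so there is nothing to lean on beyond the spread of the values themselves, which all fall within a fairly narrow band. Compound 4 is therefore expected to land close to the value of compound 1. The expected step is a 1.1-fold lower number from compound 1 to compound 4 (0.03 log units; within the scatter), which is not expected to reach beyond the scatter. The estimate for compound 4 in this assay is 60000 nM, with a range from 30000 nM to 120000 nM.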

Compound 4, half-maximal cytotoxic concentration: 57400 nM
Compound 4: middle estimate off by 1.0-fold (0.02 log units), on the high side; the range from low to high includes it.
By their numbers in this assay, from the lowest: compounds 2, 3, 4 and 1 (each within the scatter of the next, the first and the last beyond it).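

Within the data shown here, this pair gives the first measured look at what inverting a stereocentre at a saturated ring carbon does in this assay; the only step available before it concerned the aromatic group on the oxygen. The inversion, from S to R as drawn, comes out as a 1.1-fold lower number from compound 1 to compound 4 (0.05 log units; within the scatter), so on this read-out the two compounds cannot be told apart, and for this compound the configuration drawn at this stereocentre makes no visible difference to the toxicity number. The comparison is a clean one, because any gap between the two numbers could have only one source: the fact that compounds 1 and 4 differ only in the configuration as drawn.

The compounds shown leave open whether the same inversion would read alike with the plain quinolin-8-yl group on the oxygen in place of 5,7-dichloroquinolin-8-yl, and whether inverting any of the other stereo elements would behave the same way. They also leave open what a group of a different kind, such as an amine or a carboxylic acid, would do in place of the aromatic group on that oxygen.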